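Moving the hydroxyl group on a shared core: working notes

The source may report more compounds than this note shows. Statements on the series, on what has been measured and on what is new or still open speak of the compounds shown alone.

All values come from a functional assay on HeLa cells (Homo sapiens) for inhibition; a lower number here means a stronger inhibitor, a higher number a weaker inhibitor.
- compound 1 `Oc1ccc(-c2cc(-c3ccccc3C(F)(F)F)cc(-c3ccccc3O)n2)cc1` gives 16500 nM
- compound 2 `Oc1ccc(-c2cc(-c3ccccc3C(F)(F)F)cc(-c3cccc(O)c3)n2)cc1` gives 17400 nM
- compound 3 `Oc1ccccc1-c1cc(-c2cccc(OC(F)(F)F)c2)cc(-c2ccccc2O)n1` gives only a limit of the assay, > 50000 nM

The change from compound 1 to compound 2 is 3-hydroxyphenyl in place of 2-hydroxyphenyl on an aromatic carbon; it made a 1.1-fold higher number from compound 1 to compound 2 (0.02 log units; within the scatter).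

Compound 3 sits at the limit of > 50000 nM in this assay, at which 1 of the 3 values shown sits, and has no number. The difference between the core of compound 3 and that of compound 1 is not broken down here.

Compound 4 `Oc1cccc(-c2cc(-c3cccc(OC(F)(F)F)c3)cc(-c3ccccc3O)n2)c1` differs from compound 3 by 3-hydroxyphenyl in place of 2-hydroxyphenyl on an aromatic carbon. This is the same kind of change as from compound 1 to compound 2, though the place differs: there it was meta to a 2-(trifluoromethyl)phenyl group and meta to a 4-hydroxyphenyl group, here it is meta to a 2-hydroxyphenyl group and meta to a large group.

For compound 4 a step that the limit leaves unreadable from compound 3 to compound 4 is expected, resting on the small step of a 1.1-fold higher number from compound 1 to compound 2 (0.02 log units; within the scatter) seen for the same change. Compound 4 is therefore estimated at 60000 nM in this assay, between 20000 nM and 200000 nM, most likely again reported only as a limit.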

Compound 4, half-maximal inhibitory concentration: 14900 nM
Beside the measured number, compound 4's estimate is 4.0-fold (0.60 log units) above it, outside the stated range (below it).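

In this assay, 3-hydroxyphenyl in place of 2-hydroxyphenyl gave an at least 3.3-fold lower number from compound 3 to compound 4 (0.52 log units; beyond the scatter), so the size of this step does not carry over from one core to the other: the same change on two cores in this assay, a 1.1-fold higher number (0.02 log units; within the scatter) from compound 1 to compound 2 and an at least 3.3-fold lower number (0.52 log units; beyond the scatter) from compound 3 to compound 4, at least 3.5-fold (0.54 log units) apart, beyond the scatter of two such steps

Compound 3 stands only at a limit of the assay, > 50000 nM, and not at a number, so the full size of the step cannot be read. With a single pair on each core, the comparison shows that the result of this change differs between these two cores, but not which difference between the cores is responsible, and it gives no rule for the wider series.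

From the compounds shown here alone, whether the hydroxyl itself is needed at the moved position remains open. Also open, going by these compounds, is how an amine or a carboxylic acid would behave there on either core.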